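The compounds below may be only part of what the source reports. "The series", "measured", "known", "first", "only" and "open" are said of these compounds alone.

Measured compounds:
compound 1, `COc1ccc(OCCOCCNC2CCCC2)cc1`: 99100 nM
compound 2, `COc1cc(OCCOCCNC2CCCC2)ccc1OCc1ccccc1`: 44600 nM
compound 3, `CC(C)(C)OC(=O)n1ccc(NCCOCCOc2ccc(OCc3ccccc3)cc2)c1`: 13000 nM

These three compounds were tested in a functional assay on SK-OV-3 cells (Homo sapiens) for inhibition, read by CCK-8 assay, with a stated time of 70 h; on this read-out lower numbers stand for stronger inhibition and higher numbers for weaker inhibition. Compound 1 gives 99100 nM, the highest number of the three, so it is the weakest inhibitor in this set. Compound 2 gives 44600 nM, a lower number, a gap beyond the usual scatter, and compound 3 gives 13000 nM, lower still, also beyond the scatter. All three share the same kind of chain with two ether oxygens ending in an amine.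

The next compound, compound 4, `COC(=O)c1ccccc1COc1ccc(OCCOCCNC2CCCC2)cc1`, has not yet been measured. It differs from compound 1 in one place: 2-(methoxycarbonyl)phenyl in place of hydrogen on a saturated chain carbon bound to an oxygen on an aromatic ring.

Within the data shown here, no direct step between measured compounds isolates this change, so the expectation rests on the set as a whole, in which the larger compounds give lower numbers than compound 1. A step of moderate size toward a lower number is expected in this assay. Compound 4 is estimated to give 30000 nM, with a range from 10000 nM to 90000 nM. That estimate corresponds to an expected step of a 3.3-fold lower number from compound 1 to compound 4 (0.52 log units; beyond the scatter).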

Compound 4, half-maximal inhibitory concentration: > 100000 nM
Compound 4: no number, only a limit (the forecaster's own chance of this, stated with the estimate: 10%); middle value at least 3.3-fold (0.52 log units) away from the limit.
By their numbers in this assay, from the lowest: compound 3; then compound 2; then compound 1. At a limit, above all of these: compound 4.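

In this assay compound 4 gives > 100000 nM, which is a limit of the assay and not a number. Placing 2-(methoxycarbonyl)phenyl in place of hydrogen on a saturated chain carbon bound to an oxygen on an aromatic ring gives a number no lower from compound 1 to compound 4 (the limit leaves the size open), so this one-place change, which no earlier pair could isolate, brings no gain in inhibition. How much weaker compound 4 may be cannot be read, and the comparison rests on a single censored value: the limit of > 100000 nM in this assay, at which 1 of the 4 values shown sits.

The compounds shown do not separate the part played by the added aromatic ring from that of the methoxycarbonyl group on it. A carboxylic acid or an amide in place of the methoxycarbonyl group, on the same ring at this position, would help to tell the two apart.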